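From a Ketone-Bearing Chain to a Naphthyl Ether

The source may report more compounds than this note shows. Statements on the series, on what has been measured and on what is new or still open speak of the compounds shown alone.

Compound 3 `CC(C)C[C@H](N)c1cc(C(F)(F)F)ccc1N1CCN(C(=O)CC(C)C(=O)c2ccc(Cl)cc2)CC1` is the weakest of the three compounds measured in an assay on HEK293 cells for displacement of a labelled ligand from Melanocortin receptor 4 (Homo sapiens) (a lower number here means a stronger inhibitor, a higher number a weaker inhibitor), giving 1100 nM. Compound 1 `Cc1cc(Cl)ccc1CC(C)C(=O)N1CCN(c2ccc(C(F)(F)F)cc2[C@@H](N)CC(C)C)CC1` gives 38 nM and compound 2 `COc1ccc(CC(C)C(=O)N2CCN(c3ccc(C(F)(F)F)cc3[C@@H](N)CC(C)C)CC2)cc1` gives 120 nM; both steps toward compound 3, a 29-fold higher number from compound 1 to compound 3 (1.46 log units; beyond the scatter) and a 9.2-fold higher number from compound 2 to compound 3 (0.96 log units; beyond the scatter), lie beyond the scatter, whereas a 3.2-fold higher number from compound 1 to compound 2 (0.50 log units; beyond the scatter) is a more modest change. Compound 4 `CC(C)C[C@H](N)c1cc(C(F)(F)F)ccc1N1CCN(C(=O)COc2cccc3ccccc23)CC1` differs from compound 3 in one place: (naphthalen-1-yl)oxy in place of 1-((4-chlorophenyl)carbonyl)ethyl on a saturated chain carbon bound to a carbonyl carbon. Within the data shown here, none of the measured steps covers this exchange. The two steps that touch the same chain, a 29-fold higher number from compound 1 to compound 3 (1.46 log units; beyond the scatter) and a 9.2-fold higher number from compound 2 to compound 3 (0.96 log units; beyond the scatter), show only that the 2-((4-chlorophenyl)carbonyl)propyl chain in compound 3 carries a clear loss relative to the benzyl-bearing chains of compounds 1 and 2. Among the measured compounds shown here, compound 4 again carries a chain of that shorter kind, now with (naphthalen-1-yl)oxy on the saturated chain carbon bound to the carbonyl carbon, but no measured pair tells how such a group compares. One therefore expects compound 4 to recover part of the loss and estimates a 3.7-fold lower number from compound 3 to compound 4 (0.56 log units; beyond the scatter) toward a lower number, with wide uncertainty. Compound 4 is estimated at 300 nM, with a range of 60 nM to 1500 nM.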

Compound 4, inhibition constant: 2600 nM
For compound 4 the middle estimate is 8.7-fold (0.94 log units) below the measured one; measured number outside the range, above it.
By their numbers in this assay, from the lowest: compound 1; then compound 2; then compound 3; then compound 4.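

In this assay the exchange of 1-((4-chlorophenyl)carbonyl)ethyl for (naphthalen-1-yl)oxy on a saturated chain carbon bound to a carbonyl carbon brought no recovery, giving a 2.4-fold higher number from compound 3 to compound 4 (0.37 log units; beyond the scatter) as a modest further loss. Set against the benzyl-bearing chains, ((naphthalen-1-yl)oxy)methyl on the carbonyl carbon gives a 22-fold higher number from compound 2 to compound 4 (1.34 log units; beyond the scatter) and a 68-fold higher number from compound 1 to compound 4 (1.84 log units; beyond the scatter) as large steps, so among these four compounds, the two with a benzyl-bearing chain hold the lowest numbers and neither of the other two chains comes near them. Nothing measured here explains why the second aromatic ring failed to restore the lost binding.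

The compounds shown leave open whether the loss follows the ether oxygen, the naphthalen-1-yl group or the unbranched chain, as no pair here changes one of these alone. A plain phenoxy group in place of (naphthalen-1-yl)oxy, or a methylene or an amine nitrogen in place of the ether oxygen, would separate these parts and show which of them governs the number at this position.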